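Methoxy added to a fluorinated core: expected tolerance

This account rests on a few compounds, and the source may have more. Where it says the series, first, only, none or still open, it means among the compounds named here.

Measured so far:
Compound 1, `COc1ccc([C@H]2CC(C)(O)[C@@H]3CC[C@@H](C)C[C@H]3O2)cc1`: 689000 nM
Compound 2, `COc1ccc([C@H]2CC(C)(O)[C@@H]3CC[C@@H](C)C[C@H]3O2)c(OC)c1`: > 937000 nM
Compound 3, `COc1ccc([C@H]2CC(C)(F)[C@@H]3CC[C@@H](C)C[C@H]3O2)cc1OC`: 20000 nM

In an ADME assay on MDCK cells (Canis lupus familiaris) for cytotoxicity, read by MTT assay, with a stated time of 48 h (a lower number here means that less compound is tolerated, a higher number that more compound is tolerated), compound 1 gives 689000 nM. For compound 2 this assay reports only a limit, > 937000 nM, and not a number. Compound 2 sits at the limit of > 937000 nM in this assay, at which 1 of the 3 values shown sits. The change between them is methoxy in place of hydrogen on an aromatic carbon, and it produced an at least 1.3-fold higher number from compound 1 to compound 2 (0.13 log units; that floor lies within the scatter). Compound 3 gives 20000 nM, the lowest of the two plain numbers; the difference between its core and that of compound 1 is not broken down here.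

Compound 4, `COc1cc([C@H]2CC(C)(F)[C@@H]3CC[C@@H](C)C[C@H]3O2)cc(OC)c1OC`, has not yet been measured. It differs from compound 3 by methoxy in place of hydrogen on an aromatic carbon. This is the same kind of change as from compound 1 to compound 2, though the surroundings differ: here the new group sits ortho to a methoxy group and meta to a large group, whereas before it sat ortho to a large group. Because the earlier step was an at least 1.3-fold higher number from compound 1 to compound 2 (0.13 log units; that floor lies within the scatter), a small step is expected, a 1.3-fold higher number from compound 3 to compound 4 (0.10 log units; within the scatter). Compound 4 is therefore estimated at 25000 nM, between 8000 nM and 80000 nM.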

Compound 4, half-maximal cytotoxic concentration: 568000 nM
Compound 4: middle estimate off by 23-fold (1.36 log units), on the low side, outside the stated range (above it).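

Placing a methoxy group on the aromatic ring of the fluorinated core in this assay gave a large step, a 28-fold higher number from compound 3 to compound 4 (1.45 log units; beyond the scatter). This shows that the change can matter a great deal on one core, but whether that size carries over to another core remains unsettled: the same change on two cores in this assay, an at least 1.3-fold higher number (0.13 log units; that floor lies within the scatter) from compound 1 to compound 2 and a 28-fold higher number (1.45 log units; beyond the scatter) from compound 3 to compound 4; the limit leaves it open whether they differ. For compound 2, the assay gives only a limit and not a number: the limit of > 937000 nM in this assay, at which 1 of the 4 values shown sits.

The two steps differ both in the core, which carries a fluorine in one pair and a hydroxyl in the other, and in where the new methoxy group sits, so the compounds shown leave open which of these goes with the large step. They also leave open how another group in the same place on the ring, such as an amine, a carboxylic acid or a longer chain, would behave on the core of compound 3.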